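Moving the Branch in a Five-Carbon Nitrogen Substituent

The source may hold more compounds than are shown below. What is called first, only, known or untested is meant among the compounds shown, and "the series" means these compounds.

In a functional assay on LNCaP cells (Homo sapiens) for inhibition, read by WST assay, with a stated time of 3 days (on this read-out lower numbers stand for stronger inhibition and higher numbers for weaker inhibition), compound 1 (`CCCn1ccnc1/C=C/C(=O)/C=C/c1coc2ccccc2c1=O`) gives 2100 nM and compound 2 (`CCCC(C)n1ccnc1/C=C/C(=O)/C=C/c1coc2ccccc2c1=O`) gives 3900 nM and these two values lie within the scatter of each other. Compound 3 (`CCC(CC)n1ccnc1/C=C/C(=O)/C=C/c1coc2ccccc2c1=O`) carries pentan-3-yl in place of 1-methylbutyl on an aromatic nitrogen. Among the measured compounds shown here, only one measured step bears on this change (a 1.9-fold higher number from compound 1 to compound 2 (0.27 log units; within the scatter)) and it stays within the scatter, so no step beyond the scatter is expected in this assay here. The expected value for compound 3 is 3200 nM within an estimated range of 1500 nM to 6500 nM (a 1.2-fold lower number from compound 2 to compound 3 (0.09 log units; within the scatter)).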

Compound 3, half-maximal inhibitory concentration: 2800 nM
The estimate for compound 3 lay 1.1-fold (0.06 log units) above the measured number, and the stated range covers the measured number.
By their numbers in this assay, from the lowest: compounds 1, 3 and 2 (each within the scatter of the next).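

In this assay, moving the branch within the five-carbon substituent, with pentan-3-yl in place of 1-methylbutyl, leaves the result within the scatter (a 1.4-fold lower number from compound 2 to compound 3 (0.14 log units; within the scatter)). Ethyl in place of hydrogen on the chain carbon bound to the aromatic nitrogen also stays within the scatter (a 1.3-fold higher number from compound 1 to compound 3 (0.12 log units; within the scatter)), so this read-out does not separate propyl, 1-methylbutyl and pentan-3-yl at this position. Nothing available gives a reason for this result.

On these data alone, whether a cyclopentyl ring, a longer chain or a chain bearing an amine would move the number beyond the scatter remains open.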